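The source may report more compounds than this note shows. Statements on the series, on what has been measured and on what is new or still open speak of the compounds shown alone.

Compound 1, `COc1cc(-c2cc(/C=C/C(=O)c3ccc(N)cc3)[nH]n2)cc(OC)c1OC`: -73%
Compound 2, `COc1cc(-c2cc(/C=C/C(=O)c3ccc(Cl)c(Cl)c3)[nH]n2)cc(OC)c1OC`: -32%
Compound 3, `COc1ccc(C(=O)/C=C/c2cc(-c3cc(OC)c(OC)c(OC)c3)n[nH]2)cc1OC`: -13%

In a functional assay on HCT-116 cells (Homo sapiens) for cytotoxicity, read by sulforhodamine B assay, with a stated time of 48 h, tested at 100 uM (a lower number here means a stronger effect, a higher number a weaker effect of the compound at the concentration tested), compound 3 gives -13%, the highest of the three numbers and thus the weakest effect of the set. The step of a number 19 percentage points higher from compound 2 to compound 3 (beyond the scatter) is modest, whereas the step of a number 60 percentage points higher from compound 1 to compound 3 (beyond the scatter) is large, as is the step of a number 41 percentage points higher from compound 1 to compound 2 (beyond the scatter). Compound 4, `COc1ccc(C(=O)/C=C/c2cc(-c3cc(OC)c(OC)c(OC)c3)n[nH]2)cc1`, differs from compound 3 by hydrogen in place of methoxy on an aromatic carbon; cut one bond further out, the change reads 3,4-dimethoxyphenyl to 4-methoxyphenyl. Going by the values given here, all three measured steps alter the aryl group on the carbonyl carbon, but each exchanges one substitution pattern for a wholly different one; none removes a single methoxy from a ring that keeps another, so no measured step bears directly on this change. The nearest point of reference is compound 3 itself. No step beyond the scatter is therefore expected in this assay. Compound 4 is expected to give -18%, within a range from -45% to 8%. The expected step is a number 5 percentage points lower from compound 3 to compound 4 (within the scatter), within the scatter.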

Compound 4, a percentage reported as activity, at one concentration (the size of the read-out at that concentration, not a potency): -10%
Beside the measured number, compound 4's estimate is 8 percentage points below it, and the stated range covers the measured number.
By their numbers in this assay, from the lowest: compound 1; then compound 2; then compounds 3 and 4 (each within the scatter of the next).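

In this assay, the result (a number 3 percentage points higher from compound 3 to compound 4 (within the scatter)) shows that hydrogen in place of methoxy on this aromatic carbon, ortho to a methoxy group, leaves the read-out within the scatter, so 3,4-dimethoxyphenyl and 4-methoxyphenyl cannot be told apart here. Compound 4 still stands clear of the other two compounds, with 4-methoxyphenyl in place of 3,4-dichlorophenyl (a number 22 percentage points higher from compound 2 to compound 4 (beyond the scatter)) and methoxy in place of amino (a number 63 percentage points higher from compound 1 to compound 4 (beyond the scatter)). Nothing available explains these steps.

The compounds shown leave open whether a hydroxy group, a fluorine atom or an ethoxy group on this carbon would also stay within the scatter of compound 3. They also leave open what an unsubstituted phenyl on the carbonyl carbon would give.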